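Chloro step across two related cores

A few compounds are considered here, and "the series" means these few. Any claim that something is new, unique, unknown or untested is made for them only; others in the source may bear on it.

Compound 1 `O=c1cc(CSC(=S)N2CCCC2)oc2ccccc12` opens the first pair. In a functional assay on HEp-2 cells (Homo sapiens) for antiproliferative activity, read by MTT assay, with a stated time of 72 h (a higher number here means a weaker inhibitor, a lower number a stronger inhibitor), compound 1 gives 9100 nM. Compound 2 `O=c1cc(CSC(=S)N2CCCC2)oc2cc(Cl)ccc12` differs from it by chloro in place of hydrogen on an aromatic carbon. In this assay compound 2 gives > 40000 nM, which is a limit of the assay and not a number. On these data alone, the step of an at least 4.3-fold higher number from compound 1 to compound 2 (0.64 log units; beyond the scatter) is thus known only as a floor, and its true size stays open because the limit of > 40000 nM in this assay, at which 1 of the 3 values shown sits, caps what the assay reports.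

Compound 3 `CC(C)N(C(=S)SCc1coc2ccccc2c1=O)C(C)C` rests on a second core; the difference between the two cores is not broken down here. In this assay compound 3 gives 3000 nM, the lower of the two plain numbers.

Compound 4 `CC(C)N(C(=S)SCc1coc2cc(Cl)ccc2c1=O)C(C)C` has not been measured. It differs from compound 3 by chloro in place of hydrogen on an aromatic carbon, the same change as between compound 1 and compound 2. The step of a 5.0-fold higher number from compound 3 to compound 4 (0.70 log units; beyond the scatter) is expected to follow the earlier one in direction, resting on an at least 4.3-fold higher number from compound 1 to compound 2 (0.64 log units; beyond the scatter), though with a real chance of a limit again. For compound 4 the estimate in this assay is 15000 nM, within 6000 nM to 45000 nM.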

Compound 4, half-maximal inhibitory concentration: 4200 nM
Compound 4: the middle estimate sits 3.6-fold (0.55 log units) above what was measured, outside the stated range (below it).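

On the core of compound 3, chloro in place of hydrogen on an aromatic carbon gives a 1.4-fold higher number from compound 3 to compound 4 (0.15 log units; within the scatter) in this assay, so this pair shows no clear separation. The change therefore does not carry over in size from one core to the other in this series: the same change on two cores in this assay, an at least 4.3-fold higher number (0.64 log units; beyond the scatter) from compound 1 to compound 2 and a 1.4-fold higher number (0.15 log units; within the scatter) from compound 3 to compound 4, at least 3.1-fold (0.49 log units) apart, beyond the scatter of two such steps Compound 2 stands at a limit of the assay and not a number, so the true size of the earlier step stays open, and two pairs set no rule for any further core: the limit of > 40000 nM in this assay, at which 1 of the 4 values shown sits.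

The compounds shown leave open whether fluoro or methoxy in place of chloro on the same aromatic carbon would follow the pair on the core of compound 1 or the pair on the core of compound 3. They also leave open how the chloro step behaves with diethylamino as the amine part on either core.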